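Moving the ester and adding methoxy on the aniline ring

This account rests on a few compounds, and the source may have more. Where it says the series, first, only, none or still open, it means among the compounds named here.

Measured so far:
compound 1 `CCS(=O)(=O)Nc1cc(-c2ccc3ncnc(Nc4cccc(C(=O)OC)c4)c3c2)cnc1OC` — 1080 nM
compound 2 `CCS(=O)(=O)Nc1cc(-c2ccc3ncnc(Nc4ccc(Cl)c(C(=O)OC)c4)c3c2)cnc1OC` — 2360 nM

Both compounds share the same core and differ only on the ring that hangs from the aromatic nitrogen. In a functional assay on BT-549 cells (Homo sapiens) for cytotoxicity, read by sulforhodamine B assay, with a stated time of 72 h (on this read-out lower numbers stand for stronger inhibition and higher numbers for weaker inhibition), compound 1 gives 1080 nM. Compound 2 gives 2360 nM, the higher of the two numbers, so compound 2 is the weaker of the measured pair; the step of a 2.2-fold higher number from compound 1 to compound 2 (0.34 log units; beyond the scatter) came from a chloro in place of hydrogen on an aromatic carbon.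

Compound 3 `CCS(=O)(=O)Nc1cc(-c2ccc3ncnc(Nc4ccc(C(=O)OC)c(OC)c4)c3c2)cnc1OC` has not yet been measured in this assay. Its change from compound 2 is 3-methoxy-4-(methoxycarbonyl)phenyl in place of 4-chloro-3-(methoxycarbonyl)phenyl on a nitrogen on an aromatic ring. Within the data shown here, this is not a repeat of the only measured step: the chloro leaves again, but the methoxycarbonyl group also sits at a different position of the ring and a methoxy group enters. The measured step shows that a single substituent change on this ring shifts the number only modestly, so a large swing is not expected, but its direction cannot be read from one step. Compound 3 is therefore estimated to land near compound 2, with the expected step of a 1.2-fold lower number from compound 2 to compound 3 (0.07 log units; within the scatter) inside a wide band, giving an estimate of 2000 nM with a range from 700 nM to 6000 nM.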

Compound 3, half-maximal inhibitory concentration: 3760 nM
For compound 3 the middle estimate is 1.9-fold (0.27 log units) below the measured one, within the range that was stated.
By their numbers in this assay, from the lowest: compound 1; then compounds 2 and 3 (each within the scatter of the next).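

In this assay the step of a 1.6-fold higher number from compound 2 to compound 3 (0.20 log units; within the scatter) comes from putting 3-methoxy-4-(methoxycarbonyl)phenyl in place of 4-chloro-3-(methoxycarbonyl)phenyl, so even this double change on the ring attached to the nitrogen leaves the two compounds indistinguishable on this read-out. Compared with the unadorned 3-(methoxycarbonyl)phenyl, the same new ring gives a 3.5-fold higher number from compound 1 to compound 3 (0.54 log units; beyond the scatter) and this step is larger than the one seen for adding chloro, which leaves compound 1 with the lowest number of the three and both more heavily substituted rings weaker than it. Nothing measured here accounts for either step.

Between compound 2 and compound 3 the chloro leaves, the methoxycarbonyl group takes a new place and a methoxy group enters all at once, so the share of each change stays open. Also open, on these data alone, is how this ring would read with a carboxylic acid or an amide in place of the methyl ester, or with a simple amine on it.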